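An Aryl Swap at the Chain End of Compound 3

The source may hold more compounds than are shown below. What is called first, only, known or untested is meant among the compounds shown, and "the series" means these compounds.

Compound 1 `COc1ccc(C(=O)c2cc(OC)c(OC)c(OC)c2)cc1N` is the smallest member of this set, and in a functional assay on PC-3 cells (Homo sapiens) for cytotoxicity, read by MTT assay, with a stated time of 72 h (a lower number here means a stronger inhibitor, a higher number a weaker inhibitor), compound 1 gives 1100 nM. Compound 2 `COc1ccc(/C=C/C(=O)Nc2cc(C(=O)c3cc(OC)c(OC)c(OC)c3)ccc2OC)cc1` carries an amide-linked chain on the amine, and in this assay compound 2 gives 11100 nM. Compound 3 `COc1cc(/C=C/C(=O)Nc2cc(C(=O)c3cc(OC)c(OC)c(OC)c3)ccc2OC)ccc1F` differs from compound 2 only in the group on a double-bonded chain carbon bound to a double-bonded chain carbon; in this assay compound 3 gives 14100 nM, the highest of the three numbers. Its nearest neighbour is compound 2, since a 1.3-fold higher number from compound 2 to compound 3 (0.10 log units; within the scatter), while compound 1 lies far below it.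

Compound 4 `COc1ccc(C(=O)c2cc(OC)c(OC)c(OC)c2)cc1NC(=O)/C=C/c1ccc(N)cc1` is the next variation at the same place: 4-aminophenyl in place of 4-fluoro-3-methoxyphenyl on a double-bonded chain carbon bound to a double-bonded chain carbon. Within the data shown here, only one measured step bears on this place, and a 1.3-fold higher number from compound 2 to compound 3 (0.10 log units; within the scatter) stayed within the scatter, so no step beyond the scatter is expected here in this assay. One therefore expects compound 4 to show a 1.3-fold lower number from compound 3 to compound 4 (0.11 log units; within the scatter). Compound 4 is accordingly estimated at 11000 nM, with a range from 4000 nM to 30000 nM.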

Compound 4, half-maximal inhibitory concentration: 15900 nM
The estimate for compound 4 lay 1.4-fold (0.16 log units) below the measured number; the range from low to high includes it.
By their numbers in this assay, from the lowest: compound 1; then compounds 2, 3 and 4 (each within the scatter of the next).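

In this assay, 4-aminophenyl in place of 4-fluoro-3-methoxyphenyl gives a 1.1-fold higher number from compound 3 to compound 4 (0.05 log units; within the scatter), and amino in place of methoxy on an aromatic carbon gives a 1.4-fold higher number from compound 2 to compound 4 (0.16 log units; within the scatter), so neither change at the chain end moves the number beyond the scatter, even though the entering group carries a hydrogen-bond donor. Among these compounds, the one large step is on the nitrogen, where (2-(4-aminophenyl)ethenyl)carbonyl in place of hydrogen gives a 14-fold higher number from compound 1 to compound 4 (1.16 log units; beyond the scatter). No measurement is available here to explain either result.

Going by these compounds, it remains open whether a carboxylic acid or a hydroxyl on the same aromatic ring would also leave the number within the scatter. On these data alone, it is also open whether a plain acetyl on the nitrogen of compound 1 would produce a step of similar size without the ethenyl chain or its aryl group.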